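Adding a methyl group: compound 2 to compound 3

The compounds below may be only part of what the source reports. "The series", "measured", "known", "first", "only" and "open" are said of these compounds alone.

In an ADME assay on L929 cells (Mus musculus) for cytotoxicity, read by resazurin assay, with a stated time of 72 h (on this read-out higher numbers stand for weaker inhibition and lower numbers for stronger inhibition), compound 1 `O=C(/C=C/c1ccc2c(c1)B(O)OC2)c1ccccc1O` gives > 10 ug/mL, which is a limit of the assay. For the measured compounds named here, compound 2 `Cc1cccc(C(=O)/C=C/c2ccc3c(c2)B(O)OC3)c1` gives 8.56 ug/mL, the only true number so far. Compound 3 `Cc1ccc(C(=O)/C=C/c2ccc3c(c2)B(O)OC3)cc1C` differs from compound 2 by methyl in place of hydrogen on an aromatic carbon. Going by the values given here, the sole measured step, an at least 1.1-fold lower number from compound 1 to compound 2 (0.06 log units; that floor lies within the scatter), is a different change, 3-methylphenyl in place of 2-hydroxyphenyl on a carbonyl carbon, so no step beyond the scatter is expected in this assay. The expected step is a 1.1-fold lower number from compound 2 to compound 3 (0.06 log units; within the scatter). For compound 3 the estimate is 7.5 ug/mL, with an expected range of 3.5 ug/mL to 12 ug/mL.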

Compound 3, half-maximal inhibitory concentration: > 10 ug/mL
Compound 3 gave a limit, no number (the forecaster's own chance of this, stated with the estimate: 25%); middle value at least 1.3-fold (0.12 log units) away from the limit.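

In this assay, methyl in place of hydrogen on an aromatic carbon, ortho to a methyl group and para to a large group, gives an at least 1.1-fold higher number from compound 2 to compound 3 (0.06 log units; that floor lies within the scatter). Compound 3 gives > 10 ug/mL, which is a limit and not a number. This position therefore takes a second methyl without any step that can be sized beyond the scatter, and the readings crowd one end of the assay: the limit of > 10 ug/mL in this assay, at which 2 of the 3 values shown sit.

Still open, from the compounds shown here alone, is how an amine or a carboxylic acid on this aromatic carbon would read. Also open, going by these compounds, is whether a true number for compound 3 would lie beyond the scatter from compound 2.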